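The source may report more compounds than this note shows. Statements on the series, on what has been measured and on what is new or still open speak of the compounds shown alone.

Three compounds share one core and were tested in a functional assay on the whole organism (strain albino) for inhibition, with Rattus norvegicus as the target, read by paw edema, with stated times of 1 h and 2 h, at a dose of 100 mg/kg by the oral route; on this read-out higher numbers stand for more inhibition at the one dose given (going by the name of the read-out) and lower numbers for less inhibition. Compound 1 `O=C(CSc1nc(-c2ccccc2)c(C(=O)O)c(=O)[nH]1)Nn1c(COc2ccc(Cl)cc2Cl)nc2ccccc2c1=O` gives 68.4%, compound 2 `N#Cc1c(Cl)nc(SCC(=O)Nn2c(COc3ccc(Cl)cc3Cl)nc3ccccc3c2=O)nc1-c1ccc(Cl)cc1` gives 68.4%, and compound 3 `N#Cc1c(Cl)nc(SCC(=O)Nn2c(COc3ccc(Cl)cc3Cl)nc3ccccc3c2=O)nc1-c1ccc(O)cc1` gives 73.7%. Among the compounds with values here, compound 2 is level with compound 1 at the digits printed, and compound 3 lies within the scatter of it: the single measured step, a number 5.3 percentage points higher from compound 2 to compound 3 (within the scatter), exchanges one halogen for a hydroxy on a distant aromatic carbon.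

Compound 4 `N#Cc1c(Nc2ccc(O)cc2)nc(SCC(=O)Nn2c(COc3ccc(Cl)cc3Cl)nc3ccccc3c2=O)nc1-c1ccc(Cl)cc1` differs from compound 2 in another place: (4-hydroxyphenyl)amino in place of chloro on an aromatic carbon. Within the data shown here, no measured step alters this position, so the only guidance is that the one change tried so far moved nothing beyond the scatter. Compound 4 is therefore expected to give 70%, between 58% and 82%, an estimated step of a number 1.6 percentage points higher from compound 2 to compound 4 (within the scatter).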

Compound 4, a percentage reported as inhibition, in the whole organism at one dose (the size of the read-out at that dose, not a potency): 91.2%
Estimate against measurement, compound 4: 21.2 percentage points below; the measured number lies above the stated range.
By their numbers in this assay, from the lowest: compounds 1, 2 and 3 (each within the scatter of the next); then compound 4.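

Unlike the earlier change on the distant aromatic ring, this one moves the number beyond the scatter in this assay: (4-hydroxyphenyl)amino in place of chloro gives a number 22.8 percentage points higher from compound 2 to compound 4 (beyond the scatter), so the aromatic carbon next to the ring nitrogen is a place where a change can count. Nothing available bears on the reason for this rise.

With a single replacement here, the shares of the amine link, the ring and the hydroxy stay apart from nothing. A plain phenylamino group or a small amine such as methylamino would begin to separate them.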